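Adding fluoro to the benzyl group of compound 3

This account rests on a few compounds, and the source may have more. Where it says the series, first, only, none or still open, it means among the compounds named here.

In a functional assay on MDA-MB-231 cells (Homo sapiens) for inhibition, read by MTT assay (a lower number here means a stronger inhibitor of growth, a higher number a weaker inhibitor of growth), compound 3 `CC1=C(/C=C/C(C)=C/C=C/C(C)=C\C(=O)NCc2ccccc2)C(C)(C)CCC1n1ccnc1` gives 5880 nM and lies within the scatter of compound 1 `CC1=C(/C=C/C(C)=C/C=C/C(C)=C\C(=O)Nc2ccc(F)cc2)C(C)(C)CCC1n1ccnc1` (4950 nM). It is a weaker inhibitor than compound 2 `CC1=C(/C=C/C(C)=C/C=C/C(C)=C\C(=O)NCc2ccc(O)cc2)C(C)(C)CCC1n1ccnc1` (2230 nM). Compound 4 `CC1=C(/C=C/C(C)=C/C=C/C(C)=C\C(=O)NCc2ccc(F)cc2)C(C)(C)CCC1n1ccnc1` carries fluoro in place of hydrogen on an aromatic carbon, para to a large group (fluoro in place of hydrogen on an aromatic carbon). Going by the values given here, two measured steps bear on this. Hydrogen in place of hydroxy on an aromatic carbon gave a modest step (a 2.6-fold higher number from compound 2 to compound 3 (0.42 log units; beyond the scatter)), but hydroxy is not fluoro. Benzyl in place of 4-fluorophenyl stayed within the scatter (a 1.2-fold higher number from compound 1 to compound 3 (0.07 log units; within the scatter)), but no measured pair isolates fluoro alone. In this assay the expected step is a 1.2-fold lower number from compound 3 to compound 4 (0.07 log units; within the scatter) and no shift beyond the scatter is expected in either direction. Compound 4 is estimated at 5000 nM (expected range 2500 nM to 10000 nM).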

Compound 4, concentration for 50% growth inhibition: 1410 nM
Estimate against measurement, compound 4: 3.5-fold (0.55 log units) above, outside the stated range (below it).
By their numbers in this assay, from the lowest: compounds 4 and 2 (each within the scatter of the next); then compounds 1 and 3 (each within the scatter of the next).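

In this assay, this place on the benzyl group clearly matters, since fluoro in place of hydrogen alone gives a 4.2-fold lower number from compound 3 to compound 4 (0.62 log units; beyond the scatter) and is the largest step in the series. Fluoro and hydroxy here stay within the scatter of each other, with a 1.6-fold lower number from compound 2 to compound 4 (0.20 log units; within the scatter), so both differ from plain benzyl. The nitrogen substituent also counts once fluoro is present: 4-fluorobenzyl gives a 3.5-fold lower number from compound 1 to compound 4 (0.55 log units; beyond the scatter), whereas plain benzyl stayed within the scatter of compound 1. No available evidence explains these shifts. Going by these compounds, whether chloro, methoxy or an amine at this same place would match fluoro remains open.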